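The compounds below may be only part of what the source reports. "The series", "measured", "known", "first", "only" and "open" are said of these compounds alone.

Series notes. Three analogues of one shared core have been run in an assay on CHO cells for displacement of a labelled ligand from adenosine receptor A3 (Homo sapiens), read by scintillation counting, with a stated time of 120 min, tested at 10 uM; a lower number here means less inhibition, a higher number more inhibition at the concentration tested (going by the name of the read-out). Compound 1 `Nc1scc(CN2CCN(c3cccc(Cl)c3Cl)CC2)c1C(=O)c1ccc(Cl)cc1` gives 0%. Compound 2 `Nc1scc(CN2CCN(c3cc(F)ccc3F)CC2)c1C(=O)c1ccc(Cl)cc1` gives 2%. Compound 3 `Nc1scc(CN2CCN(CCCc3ccc(Cl)cc3)CC2)c1C(=O)c1ccc(Cl)cc1` gives 0%. All three numbers sit within the scatter of one another: a number 2 percentage points higher from compound 1 to compound 2 (within the scatter), no change at the digits printed from compound 1 to compound 3 (within the scatter) and a number 2 percentage points lower from compound 2 to compound 3 (within the scatter). Compound 3 stands level with compound 1 at the digits printed, the two together the lowest of the three, with compound 2 the furthest off and still within the scatter.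

Compound 4 `Nc1scc(CN2CCN(c3c(Cl)cccc3Cl)CC2)c1C(=O)c1ccc(Cl)cc1` is the next candidate. It differs from compound 3 in a single place: 2,6-dichlorophenyl in place of 3-(4-chlorophenyl)propyl on an amine nitrogen in a ring. Within the data shown here, the steps that bear on this are the two that swap the group on the same ring nitrogen between an aryl and the 3-(4-chlorophenyl)propyl chain, namely no change at the digits printed from compound 1 to compound 3 (within the scatter) and a number 2 percentage points lower from compound 2 to compound 3 (within the scatter), neither beyond the scatter, and the aryl-to-aryl step a number 2 percentage points higher from compound 1 to compound 2 (within the scatter), also flat. Among the measured compounds shown here, no step in this set moves the read-out, so no step beyond the scatter is expected for a number 1 percentage points higher from compound 3 to compound 4 (within the scatter). Compound 4 is therefore estimated at 1%, with a range of -6% to 10% in this assay.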

Compound 4, a percentage reported as inhibition, at one concentration (the size of the read-out at that concentration, not a potency): 1%
Compound 4: the middle estimate sits on the measured number at the digits printed, and the stated range covers the measured number.
By their numbers in this assay, from the lowest: compounds 1, 3, 4 and 2 (each within the scatter of the next).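

In this assay, 2,6-dichlorophenyl on the amine nitrogen in the ring gives a number 1 percentage points higher from compound 3 to compound 4 (within the scatter) and a number 1 percentage points lower from compound 2 to compound 4 (within the scatter) and a number 1 percentage points higher from compound 1 to compound 4 (within the scatter) as the steps to this compound. The last of these steps keeps both chlorine atoms on the phenyl ring and changes only their placement, so the flat picture at this nitrogen now extends to a swap between two dichlorophenyl isomers, with none of the four compounds going against it. Nothing measured on these compounds accounts for the flat read-out.

On these data alone, whether any group at this nitrogen can lift the read-out, or whether the shared core holds it flat whatever sits there, stays open. A carboxylic acid on a longer chain, an amide or a pyridine ring in this place would test that.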